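This account rests on a few compounds, and the source may have more. Where it says the series, first, only, none or still open, it means among the compounds named here.

Working notes on the series. Within the data shown here, in a functional assay on HEK293 cells for positive allosteric modulation of metabotropic glutamate receptor 5 (Homo sapiens), read by FLIPR and calcium flux (on this read-out lower numbers stand for an effect already at smaller amounts and higher numbers for an effect only at larger amounts of compound), compound 1 `O=C(COCc1ccccc1)N1CCN(c2ccc(F)cc2F)CC1` gives 300 nM and compound 2 `O=C(COCc1cnccn1)N1CCN(c2ccc(Cl)cc2Cl)CC1` gives 5200 nM; compound 2 therefore stands highest of the two numbers so far, with compound 1 the nearest and its number clearly lower, beyond the scatter. Compound 3 `N#Cc1ccc(COCC(=O)N2CCN(c3ccc(Cl)cc3Cl)CC2)s1` carries the change 5-cyanothiophen-2-yl in place of pyrazin-2-yl on a saturated chain carbon bound to an oxygen on a saturated carbon on the core shared with compound 2. Among the measured compounds shown here, no comparable step is measured in the set, so the direction rests on the structural change alone; for compound 3 a moderate drop in number is expected, the step of a 3.5-fold lower number from compound 2 to compound 3 (0.54 log units; beyond the scatter) remaining uncertain. In this assay compound 3 is estimated at 1500 nM, within 400 nM to 6000 nM.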

Compound 3, half-maximal effective concentration: 210 nM
Beside the measured number, compound 3's estimate is 7.1-fold (0.85 log units) above it, outside the stated range (below it).
By their numbers in this assay, from the lowest: compounds 3 and 1 (each within the scatter of the next); then compound 2.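

In this assay the group on a saturated chain carbon bound to an oxygen on a saturated carbon matters strongly: 5-cyanothiophen-2-yl in place of pyrazin-2-yl gives a 25-fold lower number from compound 2 to compound 3 (1.39 log units; beyond the scatter) on an otherwise unchanged core. The step is large although both groups count the same number of hydrogen-bond acceptors. Nothing measured here bears on the reason for this step.

On these data alone, whether the nitrile or the thiophene ring carries the step stays open. Unsubstituted thiophen-2-yl and a primary carboxamide in place of the nitrile would separate the two.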